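The source may report more compounds than this note shows. Statements on the series, on what has been measured and on what is new or still open speak of the compounds shown alone.

Compound 1 `COc1cc2c(cc1OC)C(=O)C(CC1CCN(C(=S)Nc3ccccc3)CC1)C2` and compound 2 `COc1cc2c(cc1OC)C(=O)C(CC1CCN(C(=S)Nc3ccc(C)cc3)CC1)C2` share one core; in a functional assay on the whole organism (strain Swiss albino) with Mus musculus as the target, with a stated time of 0.5 h (on this read-out lower numbers stand for an effect already at smaller amounts and higher numbers for an effect only at larger amounts of compound), compound 1 gives 100 mg/kg, and compound 2 gives 100 mg/kg, so that no change at the digits printed from compound 1 to compound 2 (within the scatter). Compound 3 `COc1cc2c(cc1OC)C(=O)C(CC1CCN(C(=S)Nc3cccc([N+](=O)[O-])c3)CC1)C2` carries a 3-nitrophenyl group on the same amide-type nitrogen, but in this assay compound 3 gives "not determined" (no result reported), so it stands on no number at all. Compound 4 `COc1cc2c(cc1OC)C(=O)C(CC1CCN(C(=S)Nc3ccc([N+](=O)[O-])cc3)CC1)C2` differs from it by 4-nitrophenyl in place of 3-nitrophenyl on an amide-type nitrogen. Among the compounds with values here, the only measured step concerns a methyl in place of hydrogen, a different kind of change, and it lies within the scatter; no measured step touches the nitro group or where it sits on the ring. No shift beyond the scatter is therefore expected, and compound 4 is estimated to give 100 mg/kg, with a range from 50 mg/kg to 200 mg/kg.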

Compound 4, minimum effective dose: 100 mg/kg
The estimate for compound 4 equals the measured number at the digits printed; the measured number falls inside the stated range.
By their numbers in this assay, from the lowest: compounds 1, 2 and 4 (each within the scatter of the next).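

In this assay the 4-nitrophenyl compound shows no change at the digits printed from compound 1 to compound 4 (within the scatter) and no change at the digits printed from compound 2 to compound 4 (within the scatter) here, so nitro joins hydrogen and methyl as a group on this aromatic carbon with no shift beyond the scatter. Nothing available explains this flat result. On these data alone, the steps involving compound 3 cannot be read, so the effect of where the nitro group sits on the ring stays open. Also open, as far as these compounds go, is whether an amine or a carboxylic acid on this aromatic carbon would shift the minimum effective dose.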